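Thiophen-2-yl to 1,3-Thiazol-5-yl: Estimating Compound 3

The source may report more compounds than this note shows. Statements on the series, on what has been measured and on what is new or still open speak of the compounds shown alone.

Measured so far:
compound 1 `CC(C)n1ncc2c(C(=O)Nc3cncnc3)cc(-c3cccs3)nc21`: 20000 nM
compound 2 `CC(C)n1ncc2c(C(=O)Nc3ccccc3F)cc(-c3cccs3)nc21`: 50000 nM

In an ADME assay on LLC-MK2 cells (Macaca mulatta) for cytotoxicity, read by spectrophotometry and crystal violet staining, with a stated time of 4 days (a higher number here means that more compound is tolerated, a lower number that less compound is tolerated), compound 2 gives 50000 nM, the highest of the two numbers measured. Among the compounds with values here, its nearest neighbour is compound 1, which gives 20000 nM; the only step measured, a 2.5-fold higher number from compound 1 to compound 2 (0.40 log units; beyond the scatter), is modest but beyond the scatter and concerns the group on the amide-type nitrogen.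

Compound 3 `CC(C)n1ncc2c(C(=O)Nc3ccccc3F)cc(-c3cncs3)nc21` keeps the 2-fluorophenyl of compound 2 and changes a different part of the molecule: 1,3-thiazol-5-yl in place of thiophen-2-yl on an aromatic carbon. Within the data shown here, no measured step touches this ring, so the step from compound 1 to compound 2 gives no direct guide to it. With nothing in the data pointing to a change, the expectation is that compound 3 stays close to compound 2 in this assay, and the estimated step of no change at the digits printed from compound 2 to compound 3 (within the scatter) is within the scatter. Compound 3 is therefore estimated at 50000 nM, with a range from 20000 nM to 100000 nM.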

Compound 3, half-maximal cytotoxic concentration: 100000 nM
Beside the measured number, compound 3's estimate is 2.0-fold (0.30 log units) below it; low and high end bracket the measured number.
By their numbers in this assay, from the lowest: compound 1; then compounds 2 and 3 (each within the scatter of the next).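

In this assay, within the data shown here, this is the first measured step at the five-membered ring on the aromatic carbon next to the ring nitrogen: with the 2-fluorophenyl group held constant, 1,3-thiazol-5-yl in place of thiophen-2-yl gives a 2.0-fold higher number from compound 2 to compound 3 (0.30 log units; within the scatter) and so cannot be told apart from no difference at all. Although the entering ring carries 1 nitrogen that thiophen-2-yl lacks, this pair shows that the swap leaves the two compounds inseparable in how much is tolerated by these monkey kidney cells, a result that holds for this one pair only. Nothing available here offers an explanation for this result.

The compounds shown leave open whether a plain phenyl ring, a pyridine ring or a saturated ring such as morpholine on this same aromatic carbon would read any differently. They also leave open whether the same ring swap would stay within the scatter alongside the pyrimidin-5-yl group of compound 1, since only the 2-fluorophenyl series carries the thiazole here.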